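A few compounds are considered here, and "the series" means these few. Any claim that something is new, unique, unknown or untested is made for them only; others in the source may bear on it.

Measured so far in a functional assay on SK-OV-3 cells (Homo sapiens) for cytotoxicity, read by sulforhodamine B assay, with a stated time of 2 days, tested at 100 uM; on this read-out lower numbers stand for less inhibition and higher numbers for more inhibition at the one concentration tested (going by the name of the read-out):

compound 1, `O=C(Nn1c(-c2cccc([N+](=O)[O-])c2)nc2c(-c3ccc(F)cc3)n[nH]c2c1=O)c1cccnc1`: 19.3%
compound 2, `O=C(Nn1c(-c2cccc([N+](=O)[O-])c2)nc2c(-c3ccco3)n[nH]c2c1=O)c1cccnc1`: -0.61%
compound 3, `O=C(Nn1c(-c2cccc([N+](=O)[O-])c2)nc2c(-c3ccc(F)cc3)n[nH]c2c1=O)c1ccccc1`: 77.7%

Three compounds share one scaffold and differ in two places. Compound 1 is the reference point. Replacing the group on the fused five-membered ring, (furan-2-yl in place of 4-fluorophenyl on an aromatic carbon), gives compound 2, and the step is a number 19.9 percentage points lower from compound 1 to compound 2 (beyond the scatter). Replacing the group on the carbonyl carbon, (phenyl in place of pyridin-3-yl on a carbonyl carbon), gives compound 3, and the step is a number 58.4 percentage points higher from compound 1 to compound 3 (beyond the scatter); this is the highest value among the three, with both other compounds beyond the scatter below it.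

Compound 4, `O=C(Nn1c(-c2cccc([N+](=O)[O-])c2)nc2c(-c3ccco3)n[nH]c2c1=O)c1ccccc1`, is not yet measured in this assay. It stands to compound 3 as compound 2 stands to compound 1: the change is furan-2-yl in place of 4-fluorophenyl on an aromatic carbon, the same change already seen once, since the place of the change is described in identical words for both pairs. The two cores on which the change is made differ by the carbonyl-carbon group noted above.

Among the measured compounds shown here, the one observed instance of this change lowered the read-out by a modest amount from a low starting level. For the measured compounds named here, compound 3 starts much higher, so a similar downward step would leave appreciable inhibition; a loss of the same order is expected because the only precedent is a number 19.9 percentage points lower from compound 1 to compound 2 (beyond the scatter), although the different core means the size could differ. The expected step is therefore a number 22.7 percentage points lower from compound 3 to compound 4 (beyond the scatter), a downward move. For compound 4 the estimated value in this assay is 55%, expected to lie between 25% and 80%.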

Compound 4, a percentage reported as inhibition, at one concentration (the size of the read-out at that concentration, not a potency): 17.9%
Estimate against measurement, compound 4: 37.1 percentage points above, outside the stated range (below it).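

In this assay, furan-2-yl in place of 4-fluorophenyl on an aromatic carbon gives a number 59.8 percentage points lower from compound 3 to compound 4 (beyond the scatter) on the core with phenyl on the carbonyl carbon, and the size of this step does not carry over from the core with pyridin-3-yl at that carbon: the same change on two cores in this assay, a number 19.9 percentage points lower (beyond the scatter) from compound 1 to compound 2 and a number 59.8 percentage points lower (beyond the scatter) from compound 3 to compound 4, 39.9 percentage points apart, beyond the scatter of two such steps

Seen from the other place of change, phenyl in place of pyridin-3-yl on a carbonyl carbon gives a number 18.5 percentage points higher from compound 2 to compound 4 (beyond the scatter), so in these four compounds the effects of the two changes do not simply add: the same change on two cores in this assay, a number 58.4 percentage points higher (beyond the scatter) from compound 1 to compound 3 and a number 18.5 percentage points higher (beyond the scatter) from compound 2 to compound 4, 39.9 percentage points apart, beyond the scatter of two such steps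

The direction of each change holds on both cores, but two pairs give no rule for predicting the size of a step on a further core, and they do not show what underlies the difference between the steps.

The compounds shown leave open whether the large read-out of compound 3 is specific to the pairing of 4-fluorophenyl with phenyl on the carbonyl carbon, or would persist with an unsubstituted phenyl or thiophen-2-yl on the aromatic carbon. Also open, as far as these compounds go, is how either change would behave with an amine in place of the nitro group, and, as each read-out comes from one concentration, how these percentages relate to potency.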